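The source may hold more compounds than are shown below. What is called first, only, known or untested is meant among the compounds shown, and "the series" means these compounds.

Measured in a functional assay on CCRF-CEM cells (Homo sapiens) for inhibition, read by MTT assay, with a stated time of 2 days, tested at 10 uM; on this read-out higher numbers stand for more inhibition at the one concentration tested (going by the name of the read-out) and lower numbers for less inhibition:
compound 1 `COC(=O)c1cc(-n2cc(-c3cc(O)ccc3O)nn2)ccc1O` gives 52%
compound 2 `COc1ccc(OC)c(-c2cn(-c3ccc(O)c(C(=O)O)c3)nn2)c1` gives 9%
compound 3 `O=C(OCCCc1ccccc1)c1cc(-n2cc(-c3cc(O)ccc3O)nn2)ccc1O` gives 81%

Compound 1 stands second highest of the three numbers: compound 3 sits above it, a number 29 percentage points higher from compound 1 to compound 3 (beyond the scatter), and compound 2 sits below it by a gap beyond the scatter. Compound 4 `COC(=O)c1cc(-n2cc(-c3ccccc3OC)nn2)ccc1O` has not been measured. It differs from compound 1 by 2-methoxyphenyl in place of 2,5-dihydroxyphenyl on an aromatic carbon.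

Going by the values given here, the only single-place step in hand, a number 29 percentage points higher from compound 1 to compound 3 (beyond the scatter), concerns the ester chain of the shared core, not the aryl group on the five-membered aromatic ring with 3 nitrogen, so it does not bear on the present change. Among the compounds with values here, compound 2 differs from compound 1 in more than one place, so its low value cannot be tied to the aryl change alone; it shows only that the one compound without 2,5-dihydroxyphenyl on that ring gave a low number in this assay.

Both hydrogen-bond donors of that aryl group are removed in compound 4. On the evidence of compound 2, which gives 9%, a drop is expected, though with wide uncertainty. Compound 4 is therefore expected to come in below compound 1, a step of a number 27 percentage points lower from compound 1 to compound 4 (beyond the scatter). The estimate for compound 4 is 25%, within a range from 5% to 55%.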

Compound 4, a percentage reported as inhibition, at one concentration (the size of the read-out at that concentration, not a potency): 6%
For compound 4 the middle estimate is 19 percentage points above the measured one; the range from low to high includes it.
By their numbers in this assay, from the lowest: compounds 4 and 2 (each within the scatter of the next); then compound 1; then compound 3.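

In this assay, the aryl group on the five-membered aromatic ring with 3 nitrogen now has a single-place read: with the methyl ester and the rest of the shared core held constant, a number 46 percentage points lower from compound 1 to compound 4 (beyond the scatter). This position is therefore not indifferent to substitution, and the loss can be tied to this one change, which compound 2 could not show since it differs from compound 1 in more than one place. The change takes the aryl group from 2 hydrogen-bond donors to 0 and from 2 hydrogen-bond acceptors to 1 at an unchanged 8 heavy atoms, but it removes both hydroxy groups and adds a methoxy group in one step, and nothing measured on these compounds explains the loss.

The compounds shown leave open whether one hydroxy group would suffice and which one, as a phenyl ring carrying a single hydroxy group, an unsubstituted phenyl or an aminophenyl group would test. They also leave open whether the longer ester chain of compound 3 would hold its higher number with 2-methoxyphenyl in this place.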